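The source may report more compounds than this note shows. Statements on the series, on what has been measured and on what is new or still open speak of the compounds shown alone.

Measured so far:
compound 1 `CCCCC1=NC2(CCCC2)C(=O)N1C(=O)COc1ccc(/C=C2/SC(=O)NC2=O)cc1` — < 100000 nM
compound 2 `O=C(COc1ccc(/C=C2\SC(=O)NC2=O)cc1)Nc1nc2ccccc2s1` — < 100000 nM
compound 3 `O=C1NC(=O)/C(=C\c2ccc(OCC(=O)N3C(=O)c4ccccc4S3(=O)=O)cc2)S1` — < 100000 nM

In a functional assay on Gurav cells (Homo sapiens) for cytotoxicity, read by sulforhodamine B assay, with a stated time of 48 h (a higher number here means a weaker inhibitor of growth, a lower number a stronger inhibitor of growth), compound 2 gives < 100000 nM, and this is a limit of the assay, not a number. Compound 1 and compound 3 are in the same position, each reported only as a limit in this assay; (the limit of < 100000 nM in this assay, at which 3 of the 3 values shown sit). Going by the values given here, no step between two measured compounds that differ in one place can be drawn from these three, so no measured change of any size is available, and no ranking among compound 1, compound 2 and compound 3 can be stated.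

Compound 4 `O=C(COc1ccc(/C=C2\SC(=O)NC2=O)cc1)Nc1ccccn1` differs from compound 2 in one place: pyridin-2-yl in place of 1,3-benzothiazol-2-yl on an amide-type nitrogen. Among the compounds with values here, with three limits and no measured step to lean on, the expected step that the limit leaves unreadable from compound 2 to compound 4 is none beyond the usual scatter. For compound 4 the estimate in this assay is 50000 nM, with a range from 10000 nM to 100000 nM, and it is expected that the assay again reports only a limit rather than a number.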

Compound 4, concentration for total growth inhibition: < 100000 nM
Compound 4: only a limit was reported (the forecaster's own chance of this, stated with the estimate: 80%); the middle value does not contradict the limit.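

Going by these compounds alone, compound 2 and compound 4 both stand only as limits in this assay and no step between them can be read. The compounds shown leave open whether pyridin-2-yl in place of 1,3-benzothiazol-2-yl on an amide-type nitrogen changes growth inhibition at all.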